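Swapping the aminocyclohexyl ether for a methylpiperidinyl ether

The source may report more compounds than this note shows. Statements on the series, on what has been measured and on what is new or still open speak of the compounds shown alone.

Compound 2 `CCS(=O)(=O)Nc1ccc(OC2CCC(N(C)C)CC2)c(-c2cn(C)c(=O)c3[nH]ccc23)c1` carries a sulfonamide, a cyclohexyl ether bearing a dimethylamino group, and the shared core. In an ADME assay on microsomes from liver (Homo sapiens) for metabolic stability, read by HPLC, using NADPH, with stated times of 5 min and 60 min, tested at 10 uM (on this read-out lower numbers stand for slow clearance and higher numbers for fast clearance), compound 2 gives < 26.7 mL/min/kg, which is a limit of the assay and not a number. Its parent, compound 1 `CCS(=O)(=O)Nc1ccc(Oc2ccccc2)c(-c2cn(C)c(=O)c3[nH]ccc23)c1`, gives < 45 mL/min/kg in this assay, again a limit. The step that the two limits leave unreadable from compound 1 to compound 2 is therefore not readable, both values sitting at limits, the limit of < 26.7 mL/min/kg in this assay, at which 1 of the 2 values shown sits, and (the limit of < 45 mL/min/kg in this assay, at which 1 of the 2 values shown sits). Compound 3 `CCS(=O)(=O)Nc1ccc(OC2CCN(C)CC2)c(-c2cn(C)c(=O)c3[nH]ccc23)c1` differs from compound 2 by 1-methylpiperidin-4-yl in place of 4-(dimethylamino)cyclohexyl on an oxygen on an aromatic ring. For the measured compounds named here, the only measured step that bears on this change is the unreadable one from compound 1 to compound 2, so no direction of change can be drawn from the data, and compound 3 is expected to fall within the scatter of compound 2, the expected step being a step that the limit leaves unreadable from compound 2 to compound 3. For compound 3 the estimated clearance is 15 mL/min/kg, ranging from 5 mL/min/kg to 30 mL/min/kg.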

Compound 3, clearance: < 28.4 mL/min/kg
Compound 3 gave a limit, no number; the forecaster's own chance of this, stated with the estimate: 60%; the middle value lies beyond the limit too.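

In this assay, compound 1, compound 2 and compound 3 all give limits and not numbers, so the steps among them cannot be read. On these data alone, what stays open is the clearance of each compound, and whether 1-methylpiperidin-4-yl and 4-(dimethylamino)cyclohexyl differ at all on this read-out.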